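This account rests on a few compounds, and the source may have more. Where it says the series, first, only, none or still open, it means among the compounds named here.

Compound 3 `Cc1nn(-c2ncnc3nc[nH]c23)c2c1C(OCc1ccc(C#N)cc1)CC(=O)N2` gives 60 nM in a functional assay on HEK293 cells for agonist activity at G-protein coupled receptor 39 (Homo sapiens), read by scintillation proximity assay and inositol phosphate accumulation, with a stated time of 75 min (on this read-out higher numbers stand for an effect only at larger amounts of compound and lower numbers for an effect already at smaller amounts), and sits at the low end of the three numbers, within the scatter of compound 1 `Cc1nn(-c2ncnc3nc[nH]c23)c2c1C(OC1CCCC1)CC(=O)N2`, which gives 62 nM. Only against compound 2 `Cc1nn(-c2ncnc3nc[nH]c23)c2c1C(OCc1ccccc1C#N)CC(=O)N2`, which gives 127 nM, does compound 3 stand beyond the scatter. All steps seen so far touch the same oxygen on a saturated carbon: a 1.0-fold lower number from compound 1 to compound 3 (0.01 log units; within the scatter), a 2.0-fold higher number from compound 1 to compound 2 (0.31 log units; beyond the scatter) and a 2.1-fold lower number from compound 2 to compound 3 (0.33 log units; beyond the scatter). Compound 4 `Cc1nn(-c2ncnc3nc[nH]c23)c2c1C(OC(=O)c1ccc(F)cc1)CC(=O)N2` carries (4-fluorophenyl)carbonyl in place of 4-cyanobenzyl on an oxygen on a saturated carbon. Going by the values given here, no measured step replaces a benzyl with a carbonyl at this position, so the closest guides are the modest shifts among the three measured compounds; a step of a 1.7-fold higher number from compound 3 to compound 4 (0.22 log units; within the scatter) is therefore expected, small and toward a higher number. Compound 4 is estimated at 100 nM, with a range of 30 nM to 350 nM.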

Compound 4, half-maximal effective concentration: 245 nM
The estimate for compound 4 lay 2.5-fold (0.39 log units) below the measured number; low and high end bracket the measured number.
By their numbers in this assay, from the lowest: compounds 3 and 1 (each within the scatter of the next); then compounds 2 and 4 (each within the scatter of the next).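

In this assay, going by these compounds alone, placing (4-fluorophenyl)carbonyl on this oxygen gives the largest steps seen at this position so far (a 4.1-fold higher number from compound 3 to compound 4 (0.61 log units; beyond the scatter); a 4.0-fold higher number from compound 1 to compound 4 (0.60 log units; beyond the scatter)). Against the 2-cyanobenzyl group, the same group does not separate (a 1.9-fold higher number from compound 2 to compound 4 (0.29 log units; within the scatter)). No available evidence bears on what lies behind these steps. Whether the carbonyl or the fluorine carries the step stays open, as the compounds shown change both at once. They also say nothing of a 4-fluorobenzyl group or an aminoethyl chain on this oxygen.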